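Trifluoromethyl in Place of Methyl on Compound 3

The source may report more compounds than this note shows. Statements on the series, on what has been measured and on what is new or still open speak of the compounds shown alone.

In an assay on IMR-32 cells for displacement of a labelled ligand from corticotropin-releasing factor receptor 1 (Homo sapiens), read by scintillation counting, with a stated time of 2 h (on this read-out lower numbers stand for stronger inhibition and higher numbers for weaker inhibition), compound 3 `CCc1nc(-c2ccc(C)cc2OC)c(CC)nc1NC(CC)CC` gives 23.7 nM, the lowest of the three numbers at hand. Compound 2 `CCc1nc(-c2ccc(Cl)cc2Cl)c(CC)nc1NC(COC)COC` gives 224 nM and compound 1 `CCc1nc(-c2ccc(Cl)cc2Cl)c(CC)nc1SC(C)CC` gives 401 nM, and both gaps to compound 3 lie beyond the scatter. Within the data shown here, the only measured step, a 1.8-fold lower number from compound 1 to compound 2 (0.25 log units; within the scatter), concerns a different change and says nothing about the substituent altered here. Compound 4 `CCc1nc(-c2ccc(C(F)(F)F)cc2OC)c(CC)nc1NC(CC)CC` differs from compound 3 by trifluoromethyl in place of methyl on an aromatic carbon. Among the measured compounds shown here, no measured step bears on this change, so nothing in the data argues for a shift beyond the scatter in this assay in either direction. Compound 4 is therefore expected to give about 20 nM, between 7 nM and 60 nM. That estimate means a step of a 1.2-fold lower number from compound 3 to compound 4 (0.07 log units; within the scatter), expected to stay within the usual scatter.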

Compound 4, inhibition constant: 5.6 nM
Compound 4: the middle estimate sits 3.6-fold (0.55 log units) above what was measured; measured number outside the range, below it.
By their numbers in this assay, from the lowest: compound 4; then compound 3; then compounds 2 and 1 (each within the scatter of the next).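

Trifluoromethyl in place of methyl on this aromatic carbon, para to a large group, gives a 4.2-fold lower number from compound 3 to compound 4 (0.63 log units; beyond the scatter) in this assay. This is the first step among these compounds to lie beyond the scatter, and it shows that this position takes a group of 4 heavy atoms with no loss of binding. Nothing at hand bears on why the number falls.

The compounds shown leave open how a nitrile, an amine or a longer chain at this position would read, and whether the same step would hold with other groups elsewhere on the shared core.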